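The source may hold more compounds than are shown below. What is called first, only, known or untested is meant among the compounds shown, and "the series" means these compounds.

Measured compounds in the series:

Compound 1 `Cc1ccc(S(=O)(=O)N2CCC(Cl)CC2)cc1`: in a functional assay on SW1573 cells (Homo sapiens) for antiproliferative activity, read by sulforhodamine B assay, with a stated time of 48 h (a lower number here means a stronger inhibitor of growth, a higher number a weaker inhibitor of growth), compound 1 gives > 100000 nM, which is a limit of the assay and not a number.
Compound 2 `CCCCCCC[C@H]1C[C@H](Cl)CCN1S(=O)(=O)c1ccc(C)cc1`: in this assay compound 2 gives > 100000 nM, again a limit.
Compound 3 `Cc1ccc(S(=O)(=O)N2CCC(Br)CC2)cc1`: in this assay compound 3 gives > 100000 nM, also a limit.

Compound 3 therefore stands at the limit, as do the two other compounds; all three values sit at the limit of > 100000 nM in this assay, at which 3 of the 3 values shown sit. The step that the two limits leave unreadable from compound 1 to compound 2 and the step that the two limits leave unreadable from compound 1 to compound 3 are each unreadable, since both ends are limits.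

Compound 4 `Cc1ccc(S(=O)(=O)N2CC[C@@H](Br)C[C@@H]2C2CCCCC2)cc1` is not yet measured. It differs from compound 3 by cyclohexyl in place of hydrogen on a saturated ring carbon. Within the data shown here, the step that bears on it is the one from compound 1 to compound 2, where a heptyl entered on a saturated ring carbon and the value stayed at the limit; that step's size is not readable. No measured step gives a direction for the cyclohexyl entering here, so no step beyond the scatter in this assay can be expected from the numbers shown. The estimate for compound 4 is 150000 nM, with a range from 30000 nM to 1000000 nM, which is expected to mean a step that the limit leaves unreadable from compound 3 to compound 4, most likely again reported only as a limit.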

Compound 4, concentration for 50% growth inhibition: 82000 nM
Compound 4: the middle estimate sits 1.8-fold (0.26 log units) above what was measured; low and high end bracket the measured number.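

In this assay, among these compounds, compound 4 gives 82000 nM, the first value that is a number and not a limit. Cyclohexyl on the saturated ring carbon next to the ring nitrogen gives an at least 1.2-fold lower number from compound 3 to compound 4 (0.08 log units; that floor lies within the scatter), so this change has a floor but no readable size, and the true step may or may not exceed the scatter. The earlier steps cannot be read, and most of the series still sits at the limit: the limit of > 100000 nM in this assay, at which 3 of the 4 values shown sit.

On these data alone, whether a phenyl or an aminomethyl group at this place would move the value clearly away from the limit remains open. Also open, as far as these compounds go, is whether cyclohexyl gives a measurable value with chloro in place of bromo on the shared core.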